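This account rests on a few compounds, and the source may have more. Where it says the series, first, only, none or still open, it means among the compounds named here.

Series notes. Compound 1 `CCCCCCCCc1ccc(C(=O)C[C@@H]2CCCN2)cc1` carries a ketone linker to the pyrrolidine ring; in a functional assay on FL5.12 cells (Mus musculus), read by flow cytometry, with a stated time of 3 h, tested at 2.5 uM (a lower number here means a weaker effect, a higher number a stronger effect of the compound at the concentration tested), compound 1 gives 28%, the lower of the two numbers recorded. Compound 2 `CCCCCCCCc1ccc(CC[C@@H]2CCCN2)cc1`, with a saturated two-carbon linker instead, gives 41% in this assay, a step up from compound 1 that lies beyond the usual scatter. Compound 3 `CCCCCCCCc1ccc(C(=O)CC[C@@H]2C[C@@H](O)CN2)cc1` is derived from compound 1 by the change ((4-hydroxypyrrolidin-2-yl)methyl in place of pyrrolidin-2-yl on a saturated chain carbon bound to a carbonyl carbon). Within the data shown here, no measured pair isolates this change; a small rise, near or within the scatter, is expected, the step from compound 1 to compound 3 estimated at a number 7 percentage points higher from compound 1 to compound 3 (within the scatter). Compound 3 is therefore expected to give about 35% in this assay, in the range 15% to 55%.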

Compound 3, a percentage reported as activity, at one concentration (the size of the read-out at that concentration, not a potency): 15%
Compound 3: middle estimate off by 20 percentage points, on the high side; the measured number falls inside the stated range.
By their numbers in this assay, from the lowest: compound 3; then compound 1; then compound 2.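

In this assay, (4-hydroxypyrrolidin-2-yl)methyl in place of pyrrolidin-2-yl on a saturated chain carbon bound to a carbonyl carbon gives a number 13 percentage points lower from compound 1 to compound 3 (beyond the scatter), the first sign that the read-out responds to a change at this position. The entering group differs in both its added methyl link and its hydroxy group, and this single step does not separate the two. Nothing available explains the drop.
Open, going by these compounds, is how an unsubstituted (pyrrolidin-2-yl)methyl group would compare with either compound. Also open, on these data alone, is whether a methoxy group or a fluorine atom in place of the hydroxy group would give a similar number.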